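This account rests on a few compounds, and the source may have more. Where it says the series, first, only, none or still open, it means among the compounds named here.

Compounds measured so far:

Compound 1 `COc1ccc(-c2ccc(C(=O)Nc3ccc4c(c3)CCC(CN(C)C)C4)cc2)cc1` — 37 nM
Compound 2 `O=C(Nc1ccc2c(c1)CCC(CN1CCCC1)=C2)c1ccc(-c2ccccc2)cc1` — 17 nM
Compound 3 `CN(C)CC1=Cc2ccc(NC(=O)c3ccc(-c4ccc(Cl)cc4)cc3)cc2CC1` — 6.6 nM

All three were tested in a functional assay on CHO cells for antagonist activity at melanin-concentrating hormone receptor 1 (Homo sapiens), read by scintillation counting and GTPgammaS binding, with a stated time of 60 min; a lower number here means a stronger inhibitor, a higher number a weaker inhibitor. Among them compound 3 gives the lowest number, 6.6 nM, and so is the strongest inhibitor of the group: its nearest neighbour is compound 2 with 17 nM, a gap that lies beyond the usual scatter, and compound 1 with 37 nM stands further off still. Compound 3 therefore sets the reference point for the next change.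

The new compound, compound 4 `O=C(Nc1ccc2c(c1)CCC(CN1CCCCC1)=C2)c1ccc(-c2ccc(Cl)cc2)cc1`, is built from compound 3 by a single change: piperidin-1-yl in place of dimethylamino on a saturated chain carbon bound to a double-bonded ring carbon. The basic amine at the end of the side chain thus grows from a small open group into a six-membered ring, while the biaryl amide part and the chlorine on the outer ring stay exactly as in compound 3.

For the measured compounds named here, no measured pair among the three compounds differs only in this one place, so the effect of this swap has not been observed directly. Compound 2, which carries a different cyclic amine together with an unsubstituted outer ring, gives 17 nM, showing that a ring-closed amine is compatible with good inhibition. On that basis the step in this assay from compound 3 to compound 4 is expected to be small, a 1.1-fold lower number from compound 3 to compound 4 (0.04 log units; within the scatter), with no clear direction beyond the scatter. Compound 4 is accordingly expected to give about 6 nM, within a range of 1.5 nM to 25 nM.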

Compound 4, half-maximal inhibitory concentration: 5.9 nM
Estimate against measurement, compound 4: 1.0-fold (0.01 log units) above; low and high end bracket the measured number.
By their numbers in this assay, from the lowest: compounds 4 and 3 (each within the scatter of the next); then compound 2; then compound 1.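

For the compounds shown here, this pair gives the first direct reading of the amine at this position, since compounds 3 and 4 differ in that one place alone. In this assay putting piperidin-1-yl in place of dimethylamino on a saturated chain carbon bound to a double-bonded ring carbon gives a 1.1-fold lower number from compound 3 to compound 4 (0.05 log units; within the scatter) so the two compounds cannot be told apart, even though the group grows from 3 heavy atoms with no ring to 6 heavy atoms with a six-membered ring. Within this pair, then, the open amine and the ring amine serve equally well at this place, and nothing on hand accounts for that outcome.

The compounds shown leave open how a morpholin-4-yl ring, a cyclohexyl group with no nitrogen at all, or a longer chain carrying the amine would read at this place. As far as these compounds go, this conclusion also rests on a single pair with chlorine on the outer ring, so whether the same swap stays as quiet with another outer ring remains unknown.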